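The compounds below may be only part of what the source reports. "The series", "measured", "known", "first", "only" and "open" are said of these compounds alone.

Working notes on the series. In a functional assay on ileum for inhibition of histamine H1 receptor (Cavia porcellus) (a higher number here means a weaker inhibitor, a lower number a stronger inhibitor), compound 1 `CCCOCCn1c(N2CCCN(C)CC2)nc2ccccc21` gives 16 nM, compound 2 `CN1CCN(c2nc3ccccc3n2CCO)CC1` gives 410 nM, and compound 3 `CCOCCn1c(N2CCNCC2)nc2ccccc21` gives 11 nM. Compound 3 sits at the low end of the three numbers; its value and that of compound 1 lie within the scatter of each other, whereas the value of compound 2 stands well beyond it. Among the compounds with values here, no pair of measured compounds differs in a single place, so no step can be read off directly.

Compound 4 `CCOCCn1c(N2CCN(CC)CC2)nc2ccccc21` is not yet measured. Relative to compound 3 the change is ethyl in place of hydrogen on an amine nitrogen in a ring.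

Within the data shown here, only three numbers exist, none of them a single-place step, so the expectation rests on the spread alone. The step from compound 3 to compound 4 in this assay is expected to be small, a 1.4-fold higher number from compound 3 to compound 4 (0.13 log units; within the scatter), not clearly beyond the scatter in either direction. Compound 4 is estimated at 15 nM, within a range of 5 nM to 50 nM.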

Compound 4, half-maximal inhibitory concentration: 18 nM
The estimate for compound 4 lay 1.2-fold (0.08 log units) below the measured number; the range from low to high includes it.
By their numbers in this assay, from the lowest: compounds 3, 1 and 4 (each within the scatter of the next); then compound 2.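

In this assay, within the data shown here, the first single-place step, ethyl in place of hydrogen on an amine nitrogen in a ring, is a 1.6-fold higher number from compound 3 to compound 4 (0.21 log units; within the scatter) and so does not separate the pair. In this one pair, that ring nitrogen carries either hydrogen or ethyl with no step beyond the scatter. Nothing at hand bears on why the two compounds read alike. Still open, on these data alone, is whether a longer chain or a benzyl group on the same nitrogen would also stay within the scatter. One pair also cannot show whether the same change behaves alike on other compounds of the series.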